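From pyridin-2-yl to pyridin-4-yl on a shared core

A few compounds are considered here, and "the series" means these few. Any claim that something is new, unique, unknown or untested is made for them only; others in the source may bear on it.

In a functional assay on PC-3 cells (Homo sapiens) for inhibition (on this read-out lower numbers stand for stronger inhibition and higher numbers for weaker inhibition), compound 1 (`Cc1c(C(=O)N/N=C\c2cccc(F)c2)oc2cccc(O)c12`) gives >= 40000 nM as a limit, not a number. Compound 2 (`Cc1c(C(=O)N/N=C\c2ccccn2)oc2cccc(O)c12`) also gives >= 40000 nM as a limit, not a number. Within the data shown here, the only measured step is a step that the two limits leave unreadable from compound 1 to compound 2 and shows no readable size, with both values at one limit (the limit of >= 40000 nM in this assay, at which 2 of the 2 values shown sit). Compound 3 (`Cc1c(C(=O)N/N=C\c2ccncc2)oc2cccc(O)c12`) has pyridin-4-yl in place of pyridin-2-yl on a carbon with a double bond to nitrogen. With no readable step to draw on, no change beyond the scatter is expected in this assay for compound 3 (a number no higher from compound 2 to compound 3 (the limit leaves the size open)). Compound 3 is estimated at 40000 nM (range 15000 nM to 80000 nM).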

Compound 3, half-maximal inhibitory concentration: >= 40000 nM
Compound 3 was reported as a limit; the forecaster's own chance of this, stated with the estimate: 75%; the middle value sits exactly at the limit.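

In this assay, among these compounds, no step among compound 1, compound 2 and compound 3 can be read, as each gives only a limit, not a number: the limit of >= 40000 nM in this assay, at which 3 of the 3 values shown sit. Going by these compounds, what stays open is how strongly each compound inhibits, and whether 3-fluorophenyl, pyridin-2-yl and pyridin-4-yl differ at all.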